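The compounds below may be only part of what the source reports. "The series", "measured", "known", "first", "only" and "open" are said of these compounds alone.

Compound 1 `O=[N+]([O-])c1cn2c(n1)OC[C@@H](OCc1cccc(-c3ccc(C(F)(F)F)cc3)c1)C2`: in an ADME assay on Vero cells (Chlorocebus sabaeus) for cytotoxicity, with a stated time of 72 h (a lower number here means a stronger inhibitor, a higher number a weaker inhibitor), compound 1 gives > 128000 nM, which is a limit of the assay rather than a number.
Compound 2 `N#Cc1ccc(-c2cccc(CO[C@@H]3COc4nc([N+](=O)[O-])cn4C3)c2)cc1`: in this assay compound 2 gives > 128000 nM, again a limit of the assay.
Compound 3 `O=[N+]([O-])c1cn2c(n1)OC[C@@H](OCc1cc(-c3ccc(C(F)(F)F)cc3)no1)C2`: in this assay compound 3 gives > 128000 nM, also a limit of the assay.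

All three measured compounds therefore sit at the same ceiling of this assay, and none of them shows a readable number. Compound 2 differs from compound 1 by one change, (cyano in place of trifluoromethyl on an aromatic carbon). The step that this change makes, a step that the two limits leave unreadable from compound 1 to compound 2, cannot be sized because the limit of > 128000 nM in this assay, at which 3 of the 3 values shown sit, holds both values at the limit; all that can be said is that neither compound reaches a measurable level of cytotoxicity.

Compound 4 `N#Cc1ccc(-c2cc(CO[C@@H]3COc4nc([N+](=O)[O-])cn4C3)on2)cc1` is not yet measured. It differs from compound 3 by cyano in place of trifluoromethyl on an aromatic carbon. Going by the values given here, this is the same change as the one from compound 1 to compound 2, made at the same place on the ring. The cores of compound 1 and compound 3 differ in a way that is not broken down here.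

Given that compound 3 sits at the limit with > 128000 nM, and that the same change from compound 1 to compound 2 left both partners at the limit, compound 4 is expected to stay at the limit as well, with an expected step that the limit leaves unreadable from compound 3 to compound 4. The estimate for compound 4 in this assay is 160000 nM, with a range from 90000 nM to 400000 nM.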

Compound 4, half-maximal inhibitory concentration: > 128000 nM
Compound 4: no number, only a limit; the forecaster's own chance of this, stated with the estimate: 85%; the middle value lies beyond the limit too.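

The step from compound 3 to compound 4, cyano in place of trifluoromethyl, cannot be read, as with the earlier pair, compound 1 and compound 2, since both partners in each pair stand at the same limit of this assay: the limit of > 128000 nM in this assay, at which 4 of the 4 values shown sit.

The compounds shown leave open at what concentration any of them would harm these cells, and whether swapping trifluoromethyl for cyano changes that concentration at all.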